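Swapping a Side Chain on Compound 1

A few compounds are considered here, and "the series" means these few. Any claim that something is new, unique, unknown or untested is made for them only; others in the source may bear on it.

- Compound 1 `NCCCCN(C[C@H]1Cc2ncccc2CN1)[C@H]1CCCc2cccnc21`: 86%
- Compound 2 `NCCCCN(C[C@H]1Cc2cccnc2CN1)[C@H]1CCCc2cccnc21`: 69%

In an ADME assay on microsomes from liver (Mus musculus) for metabolic stability, using NADPH, with a stated time of 10 min (a higher number here means that more of the compound is left, a lower number that less of the compound is left), compound 1 gives 86%, the higher of the two numbers, and compound 2 gives 69%. The gap between these two compounds lies beyond the scatter. Compound 3 `NC(=O)NC/C=C\CN(C[C@H]1Cc2ncccc2CN1)[C@H]1CCCc2cccnc21` keeps the core of compound 1 and changes one part: a group of 7 heavy atoms (4 carbon, 2 nitrogen, 1 oxygen; no ring) in place of a group of 4 heavy atoms (3 carbon, 1 nitrogen; no ring), on a saturated chain carbon bound to an amine nitrogen. Within the data shown here, no measured pair shows a change of this kind, so the expectation rests only on compound 1 at 86%. In this assay the expected step is a number 6 percentage points lower from compound 1 to compound 3 (within the scatter), a small drop within the scatter. Compound 3 is estimated at 80%, with an expected range from 60% to 95%.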

Compound 3, percent of the compound remaining: 10%
For compound 3 the middle estimate is 70 percentage points above the measured one; measured number below the stated range.
By their numbers in this assay, from the lowest: compound 3; then compound 2; then compound 1.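

Compound 1 and compound 2 both carry the 3-aminopropyl group, so only compound 3 shows a change at this place, on a saturated chain carbon bound to an amine nitrogen. In this assay the swap brings a number 76 percentage points lower from compound 1 to compound 3 (beyond the scatter), so the group at this place can strongly affect how much compound is left. No available measurement explains this drop.

The compounds shown leave open which part of the entering group matters, its chain double bond or its end group. A saturated chain with the same carbonyl-bearing end, or the same unsaturated chain ending in an amine, would separate the two.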